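Replacing 4-methoxyphenyl in the highest-number compound of the series

A few compounds are considered here, and "the series" means these few. Any claim that something is new, unique, unknown or untested is made for them only; others in the source may bear on it.

Measured so far in a functional assay on MGC-803 cells (Homo sapiens) for inhibition, read by MTT assay, with a stated time of 72 h; on this read-out higher numbers stand for weaker inhibition and lower numbers for stronger inhibition:
compound 1 `CCCCc1ccc(NC(=O)C2CCN(C/C=C/c3ccccc3)CC2)cc1` gives 2570 nM
compound 2 `CCCCCc1ccc(NC(=O)C2CCN(C/C=C/c3ccccc3)CC2)cc1` gives 2550 nM
compound 3 `COc1ccc(NC(=O)C2CCN(C/C=C/c3ccccc3)CC2)cc1` gives 58200 nM
Not yet measured: compound 4 `O=C(Nc1ccc(F)c(Br)c1)C1CCN(C/C=C/c2ccccc2)CC1`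

Compound 3 stands highest of the three at 58200 nM and is the weakest inhibitor here, with its steps to both others beyond the scatter. The change to follow is 3-bromo-4-fluorophenyl in place of 4-methoxyphenyl on an amide-type nitrogen with 3-bromo-4-fluorophenyl entering where 4-methoxyphenyl leaves, on an amide-type nitrogen.

For the measured compounds named here, two measured steps bear on it. These are a 23-fold higher number from compound 1 to compound 3 (1.35 log units; beyond the scatter) and a 23-fold higher number from compound 2 to compound 3 (1.36 log units; beyond the scatter) and both are large, with methoxy going with the higher number in these compounds. The step of a 1.0-fold lower number from compound 1 to compound 2 (0.00 log units; within the scatter) lies within the scatter, so butyl and pentyl give one level to compare against. Going by the values given here, no measured compound carries bromo or fluoro, so these steps show only that this group matters, not where the new group will land.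

A move away from compound 3 toward lower numbers is therefore expected, somewhat smaller than the two methoxy steps. The expected step is an 8.3-fold lower number from compound 3 to compound 4 (0.92 log units; beyond the scatter) in this assay as an estimate only. For compound 4 the estimate is 7000 nM and the expected range runs from 1500 nM to 30000 nM on this read-out.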

Compound 4, half-maximal inhibitory concentration: 9270 nM
Compound 4: the middle estimate sits 1.3-fold (0.12 log units) below what was measured; measured number inside the range.
By their numbers in this assay, from the lowest: compounds 2 and 1 (each within the scatter of the next); then compound 4; then compound 3.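

In this assay, the step of a 6.3-fold lower number from compound 3 to compound 4 (0.80 log units; beyond the scatter) shows that the high number of compound 3 does not extend to every ring without an alkyl chain: 3-bromo-4-fluorophenyl on the amide-type nitrogen gives a clearly lower number than 4-methoxyphenyl. Even so, compound 4 at 9270 nM stands above compound 1 at 2570 nM and compound 2 at 2550 nM, so among these four compounds the butyl and pentyl rings keep the lowest numbers, and no compound goes against that order. No measurement at hand bears on the cause of the step.

Compound 4 brings bromo and fluoro in together, so the step cannot be divided between them, and the 3-bromophenyl and 4-fluorophenyl groups, each on the same amide-type nitrogen, would be needed to separate the two. Also open, going by these compounds, is where an amine or a carboxylic acid on the ring, or a chain longer than pentyl, would fall relative to the level set by butyl and pentyl.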